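From Fluoro to Bromo: One Swap Awaiting Its Number

The source may hold more compounds than are shown below. What is called first, only, known or untested is meant among the compounds shown, and "the series" means these compounds.

Compound 1 `O=C(Nc1ccc(Oc2ccnc3[nH]ccc23)cc1)c1cn(-c2ccc(Br)cc2)c2ccccc2c1=O`: 220 nM
Compound 2 `Cn1ccc2c(Oc3ccc(NC(=O)c4cn(-c5ccc(Br)cc5)c5ccccc5c4=O)cc3F)ccnc21`: 1260 nM
Compound 3 `O=C(Nc1ccc(Oc2ccnc3[nH]ccc23)c(F)c1)c1cn(-c2ccc(F)cc2)c2ccccc2c1=O`: 270 nM

All three were tested in a functional assay on HepG2 cells (Homo sapiens) for inhibition, read by MTT assay, with a stated time of 72 h; on this read-out lower numbers stand for stronger inhibition and higher numbers for weaker inhibition. Compound 3 holds the second highest of the three numbers; compound 1 sits close to it, within the usual scatter, while compound 2 lies well above, beyond the scatter. Compound 4 `O=C(Nc1ccc(Oc2ccnc3[nH]ccc23)c(F)c1)c1cn(-c2ccc(Br)cc2)c2ccccc2c1=O` has not yet been measured. It differs from compound 3 in one place: bromo in place of fluoro on an aromatic carbon. Among the measured compounds shown here, no measured pair differs in exactly this way, so the size of the step is unknown from direct comparison. Because compound 1 with its 4-bromophenyl group gives 220 nM close to compound 3, the step of a 1.2-fold lower number from compound 3 to compound 4 (0.07 log units; within the scatter) is expected to stay within the scatter. Compound 4 is therefore estimated at 230 nM, with a range from 100 nM to 550 nM.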

Compound 4, half-maximal inhibitory concentration: 710 nM
Compound 4: middle estimate off by 3.1-fold (0.49 log units), on the low side; the measured number lies above the stated range.
By their numbers in this assay, from the lowest: compounds 1 and 3 (each within the scatter of the next); then compounds 4 and 2 (each within the scatter of the next).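

In this assay the change from 4-fluorophenyl to 4-bromophenyl matters on this core, giving a 2.6-fold higher number from compound 3 to compound 4 (0.42 log units; beyond the scatter) as a modest step beyond the scatter. With the 4-bromophenyl group kept, fluoro in place of hydrogen on an aromatic carbon gives a 3.2-fold higher number from compound 1 to compound 4 (0.51 log units; beyond the scatter) as a step of similar size, so compound 4 reads weaker than both compound 1 and compound 3. Hydrogen in place of methyl on an aromatic nitrogen gives a 1.8-fold lower number from compound 2 to compound 4 (0.25 log units; within the scatter) and stays within the scatter.

Nothing available explains these steps. On these data alone, how a chloro or methoxy group would read at this place on the ring remains open.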